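A few compounds are considered here, and "the series" means these few. Any claim that something is new, unique, unknown or untested is made for them only; others in the source may bear on it.

Measured so far in an ADME assay on Vero cells (Chlorocebus sabaeus) for cytotoxicity, read by MTT assay, with a stated time of 72 h; on this read-out lower numbers stand for higher toxicity in this test and higher numbers for lower toxicity in this test:
- compound 1, `C[C@]1(CN2CCc3nc(N4CCC(F)(F)CC4)ccc3C2)Cn2cc([N+](=O)[O-])nc2O1`: "not determined" (no result reported)
- compound 2, `C[C@]1(CN2CCc3nc(-c4cc(F)ccc4F)ccc3C2)Cn2cc([N+](=O)[O-])nc2O1`: > 32 ug/mL
- compound 3, `C[C@]1(CN2CCc3nc(-c4cc(F)cc(Cl)c4)ccc3C2)Cn2cc([N+](=O)[O-])nc2O1`: > 32 ug/mL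

Compound 1 has no number in this assay; its entry there is simply "not determined" (no result reported). Compound 2 sits at a limit of the test, > 32 ug/mL. Compound 3 likewise sits at a limit, > 32 ug/mL. Going by the values given here, the one measured step, a step that the two limits leave unreadable from compound 2 to compound 3, therefore carries no readable size; what both compounds share is the limit of > 32 ug/mL in this assay, at which 2 of the 3 values shown sit. Compound 4, `C[C@]1(CN2CCc3nc(-c4cc(F)c(F)c(F)c4)ccc3C2)Cn2cc([N+](=O)[O-])nc2O1`, differs from compound 1 in one place: 3,4,5-trifluorophenyl in place of 4,4-difluoropiperidin-1-yl on an aromatic carbon. Among the compounds with values here, no measured step swaps one of these two groups for the other, and compound 1 itself carries no number, so no step size can be read for this change. What the two measured values show is that compound 2 with 2,5-difluorophenyl and compound 3 with 3-chloro-5-fluorophenyl both reach the limit of this assay. Compound 4, with 3,4,5-trifluorophenyl, is expected to reach that limit as well, with an estimated value of 45 ug/mL in a range from 20 ug/mL to 100 ug/mL.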

Compound 4, half-maximal cytotoxic concentration: > 32 ug/mL
Compound 4: only a limit was reported (the forecaster's own chance of this, stated with the estimate: 85%); the middle value is on the limit's open side.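

No new step can be read, since compound 2, compound 3 and compound 4 all stop at the same limit in this assay: the limit of > 32 ug/mL in this assay, at which 3 of the 4 values shown sit. On these data alone, what stays open is how far the true values of these three compounds lie past that limit, and whether they differ at all.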